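The source may hold more compounds than are shown below. What is called first, only, known or untested is meant among the compounds shown, and "the series" means these compounds.

Measured so far:
compound 1, `Cc1cccc(-n2cnc3cc(C(=O)N4CCC(Br)CC4)ccc32)c1`, giving 76 nM
compound 2, `Cc1cccc(-n2cnc3cc(C(=O)N4CCC(C(F)(F)F)CC4)ccc32)c1`, giving 1520 nM

Both were tested in an assay on isolated protein for inhibition of 15-hydroxyprostaglandin dehydrogenase [NAD(+)] (Homo sapiens), read by fluorescence, with a stated time of 15 min; a higher number here means a weaker inhibitor, a lower number a stronger inhibitor. Among the measured compounds shown here, compound 1 holds the lower of the two numbers; the only measured step, a 20-fold higher number from compound 1 to compound 2 (1.30 log units; beyond the scatter), separates it from compound 2. Compound 3, `CCCCNC(=O)c1ccc2c(c1)ncn2-c1cccc(C)c1`, is not yet measured. It differs from compound 1 in one place: butylamino in place of 4-bromopiperidin-1-yl on a carbonyl carbon. For the measured compounds named here, no measured step reproduces this exchange; the step from compound 1 to compound 2 bears on it only in that it sits at the same carbonyl and shows that a single change there moved the number a long way. On that basis compound 3 is expected to give a higher number than compound 1, by a step of roughly a 6.6-fold higher number from compound 1 to compound 3 (0.82 log units; beyond the scatter), with wide uncertainty since the entering butylamino carries no ring and one hydrogen-bond donor where the leaving group had neither. The estimate for compound 3 is 500 nM, within 100 nM to 3000 nM.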

Compound 3, half-maximal inhibitory concentration: 1360 nM
Beside the measured number, compound 3's estimate is 2.7-fold (0.43 log units) below it; the range from low to high includes it.
By their numbers in this assay, from the lowest: compound 1; then compounds 3 and 2 (each within the scatter of the next).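

Exchanging 4-bromopiperidin-1-yl for butylamino on the carbonyl carbon gives, in this assay, an 18-fold higher number from compound 1 to compound 3 (1.25 log units; beyond the scatter), so the number moves a long way not only when the ring stays and its substituent changes, but also when the ring itself is gone. The ring-free compound 3 at 1360 nM and the ring-bearing compound 2 at 1520 nM lie within the scatter of each other, so these two exchanges cannot be told apart here. No evidence at hand explains either rise in the number.

The compounds shown leave open whether the low number of compound 1 rests on the bromo or on the piperidine ring, which unsubstituted piperidin-1-yl or a chloro in place of bromo would help separate. They also leave open whether dibutylamino, which lacks the amide hydrogen, would behave like butylamino.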